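Removing the Amide Entirely: From Compound 3 to Compound 4

The compounds below may be only part of what the source reports. "The series", "measured", "known", "first", "only" and "open" are said of these compounds alone.

Three compounds share one core and differ only in the amide on the fused ring system. In a functional assay on HeLa cells (Homo sapiens) for antiproliferative activity, read by CCK-8 assay, with a stated time of 72 h (a higher number here means a weaker inhibitor of growth, a lower number a stronger inhibitor of growth), compound 1 `CC[C@@H]1C(=O)N(C)c2cnc(-n3ccc4cc(C(=O)NCC(C)C)ccc43)nc2N1C1CCCC1` gives 3280 nM, compound 2 `CC[C@@H]1C(=O)N(C)c2cnc(-n3ccc4cc(C(=O)NC5CCCC5)ccc43)nc2N1C1CCCC1` gives 247 nM, and compound 3 `CCNC(=O)c1ccc2c(ccn2-c2ncc3c(n2)N(C2CCCC2)[C@H](CC)C(=O)N3C)c1` gives 418 nM. Compound 3 stands second highest of the three: its number and that of compound 2 are within the scatter of each other, while compound 1 sits clearly higher, a step of a 7.8-fold lower number from compound 1 to compound 3 (0.89 log units; beyond the scatter).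

Compound 4 `CC[C@@H]1C(=O)N(C)c2cnc(-n3ccc4ccccc43)nc2N1C1CCCC1` goes further than any measured step. The change is hydrogen in place of ethylcarbamoyl on an aromatic carbon, so the ethylcarbamoyl is gone and only hydrogen remains at that aromatic carbon. The measured steps all kept an amide in place and varied only what sat on its nitrogen: a 13-fold lower number from compound 1 to compound 2 (1.12 log units; beyond the scatter) and a 1.7-fold higher number from compound 2 to compound 3 (0.23 log units; within the scatter). None of them shows what happens when the amide itself is removed, so there is no direct guide. What the measured compounds do show is that this position responds to substitution, and the amide is present in every compound with a low number. The expectation is therefore a shift to a higher number, with wide uncertainty. Compound 4 is estimated at 1500 nM, in the range 350 nM to 7000 nM, an expected step of a 3.6-fold higher number from compound 3 to compound 4 (0.55 log units; beyond the scatter).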

Compound 4, concentration for 50% growth inhibition: 33900 nM
Estimate against measurement, compound 4: 23-fold (1.35 log units) below, and the stated range ends below it.
By their numbers in this assay, from the lowest: compounds 2 and 3 (each within the scatter of the next); then compound 1; then compound 4.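

For the compounds shown here, the amide turns out to matter far more than the earlier compounds could show, since each of them carried one. In this assay, replacing the amide with hydrogen on this aromatic carbon gives an 81-fold higher number from compound 3 to compound 4 (1.91 log units; beyond the scatter) when ethylcarbamoyl leaves and a 140-fold higher number from compound 2 to compound 4 (2.14 log units; beyond the scatter) when cyclopentylcarbamoyl leaves, and even compound 1, the weakest of the amides, loses further ground, with a 10-fold higher number from compound 1 to compound 4 (1.01 log units; beyond the scatter) when isobutylcarbamoyl leaves. All three amides therefore give a clearly lower number than hydrogen does, making compound 4 the weakest inhibitor of growth of the four, so what sits on the amide nitrogen changes the number, but the presence of the amide has the larger effect for compounds 2 and 3 and one of similar size to the chain change for compound 1. Nothing available here explains why this group counts for so much.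

The compounds shown leave open whether the amide itself is required or whether another group on this carbon could serve as well, such as a carboxylic acid, a nitrile or an aminomethyl group. They also do not show how the plain carbamoyl group, with only hydrogens on its nitrogen, would compare with the ethylcarbamoyl and cyclopentylcarbamoyl groups.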